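Chloro on the Benzimidazole: Compound 3 to Compound 4

The source may hold more compounds than are shown below. What is called first, only, known or untested is meant among the compounds shown, and "the series" means these compounds.

Measured so far:
Compound 1, `CC(=O)N1CCc2c(c(-c3ccc(Cl)c(C)c3)nn2CC(O)CN2CCC(n3c(=O)n(C)c4ccccc43)CC2)C1`: 500 nM
Compound 2, `CC(=O)N1CCc2c(c(-c3ccc(Br)cc3)nn2CC(O)CN2CCC(n3c(O)nc4ccc(Cl)cc43)CC2)C1`: 120 nM
Compound 3, `Cc1cc(-c2nn(CC(O)CN3CCC(n4c(O)nc5ccccc54)CC3)c3c2CN(S(C)(=O)=O)CC3)ccc1Cl`: 60 nM

In an assay on isolated protein for inhibition of cathepsin S (Homo sapiens) (a lower number here means a stronger inhibitor, a higher number a weaker inhibitor), compound 3 gives the lowest of the three numbers. Its nearest neighbour is compound 2, whose value sits within the usual scatter of compound 3, so the two cannot be ranked against each other. Compound 1 lies clearly higher, beyond the scatter.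

Compound 4, `Cc1cc(-c2nn(CC(O)CN3CCC(n4c(O)nc5ccc(Cl)cc54)CC3)c3c2CN(S(C)(=O)=O)CC3)ccc1Cl`, has not yet been measured. It is built from compound 3 by one change: chloro in place of hydrogen on an aromatic carbon. Compound 2 already carries the same 6-chloro-2-hydroxy-1H-benzimidazol-1-yl group, and in this assay compound 2 gives 120 nM, close to compound 3. Among the measured compounds shown here, no direct pair with only this change has been measured, so the size of its effect is unknown; the expectation is a step of a 1.5-fold lower number from compound 3 to compound 4 (0.18 log units; within the scatter), small and at most at the edge of the scatter, pointing slightly toward a lower number. Compound 4 is therefore estimated at 40 nM, with a range from 15 nM to 120 nM.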

Compound 4, half-maximal inhibitory concentration: 50 nM
Beside the measured number, compound 4's estimate is 1.3-fold (0.10 log units) below it, and the stated range covers the measured number.
By their numbers in this assay, from the lowest: compounds 4, 3 and 2 (each within the scatter of the next, the first and the last beyond it); then compound 1.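

In this assay, chloro in place of hydrogen on an aromatic carbon, which turns 2-hydroxy-1H-benzimidazol-1-yl into 6-chloro-2-hydroxy-1H-benzimidazol-1-yl, gives a 1.2-fold lower number from compound 3 to compound 4 (0.08 log units; within the scatter). This is the first pair among these compounds that differs only by this chloro, so its effect can now be read directly: with the rest of compound 3 held fixed, the position accepts a chlorine with no change beyond the scatter. Nothing available explains why the number stays within the scatter.

Going by these compounds, whether a different group at this position, such as a methoxy group, an amine or a carboxylic acid, would also stay within the scatter or move the number beyond it remains open. Whether chloro has an equally small effect on another background, such as that of compound 2, is also unresolved.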